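Changing the Aryl Group on the Amine Nitrogen

A few compounds are considered here, and "the series" means these few. Any claim that something is new, unique, unknown or untested is made for them only; others in the source may bear on it.

Of the compounds shown here, two have so far been measured in a functional assay on the whole organism (strain Wistar) for inhibition, with Rattus norvegicus as the target, read by paw edema, with a stated time of 4 h, at a dose of 10 mg/kg by the oral route; on this read-out lower numbers stand for less inhibition and higher numbers for more inhibition at the one dose given (going by the name of the read-out). Compound 1 `Clc1ccc(-c2nnc(COc3ccc(-c4ccccc4)cc3)o2)c(Cl)c1` gives 57.6%, and compound 2 `Clc1ccc(Nc2nnc(COc3ccc(-c4ccccc4)cc3)s2)cc1` gives 54.5%. Compound 2 holds the lower of the two numbers, but its gap to compound 1 lies within the scatter of repeated measurements, so the two compounds stand level on this read-out. Within the data shown here, no pair of measured compounds differs in only one place, so no measured step is available to guide the next change.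

Compound 3 `Cc1ccc(Nc2nnc(COc3ccc(-c4ccccc4)cc3)s2)c(C)c1` has not yet been measured in this assay. Its difference from compound 2 is 2,4-dimethylphenyl in place of 4-chlorophenyl on a nitrogen on an aromatic ring. Among the measured compounds shown here, nothing measured shows what such a change does to the read-out; the only anchor is the value of compound 2 itself. The step of a number 2.5 percentage points lower from compound 2 to compound 3 (within the scatter) is expected to be no larger than the scatter, in either direction. The estimate for compound 3 in this assay is 52%, with a range from 38% to 66%.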

Compound 3, a percentage reported as inhibition, in the whole organism at one dose (the size of the read-out at that dose, not a potency): 56.8%
Estimate against measurement, compound 3: 4.8 percentage points below; measured number inside the range.
By their numbers in this assay, from the lowest: compounds 2, 3 and 1 (each within the scatter of the next).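

Among these compounds, the 2,4-dimethylphenyl for 4-chlorophenyl exchange on the nitrogen gives the first one-place comparison in this assay, and it reads a number 2.3 percentage points higher from compound 2 to compound 3 (within the scatter). At this position, then, a phenyl ring bearing two methyl groups and one bearing a single chlorine stand level at the one dose given, so this exchange does not separate the two compounds on this read-out. Nothing measured beyond the read-out itself bears on this result.

Among the compounds shown here, only these two groups can be compared on this nitrogen, both with one six-membered aromatic ring of carbon only, and compound 1 differs from them in more than one place, so it offers no step that speaks to this position. Still open, as far as these compounds go, is whether a group of another kind on this nitrogen, such as a pyridine ring, or a phenyl ring carrying a carboxylic acid or a dimethylamino group, would stand apart from these compounds, and whether a single dose and time point would show the same picture across a range of doses.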